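Replacing fluoro with methyl on compound 1

The compounds below may be only part of what the source reports. "The series", "measured", "known", "first", "only" and "open" are said of these compounds alone.

Compound 1 (`O=C1/C(=C/c2cccc(F)c2)CCc2ccccc21`): 31100 nM
Compound 2 (`O=C1/C(=C/c2ccc(Br)cc2)CCc2ccccc21`): 20400 nM

Both numbers come from a functional assay on P388 cells (Mus musculus) for inhibition; a higher number here means a weaker inhibitor, a lower number a stronger inhibitor. They lie within the usual scatter of repeated measurements, so compound 1 cannot be ranked against compound 2 on these data. The two simply sit in the same range.

Compound 3 (`Cc1cccc(/C=C2\CCc3ccccc3C2=O)c1`) has not been measured yet. It keeps the core of compound 1 and changes a single group: methyl in place of fluoro on an aromatic carbon. In words, this is methyl in place of fluoro on an aromatic carbon, meta to a large group.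

Among the compounds with values here, no two measured compounds differ in just one place, so the data offer no direct measure of what a single swap does here. Within the data shown here, the only guide is how close together the two measured values are, with compound 1 at 31100 nM and compound 2 at 20400 nM. With so little to go on, no shift beyond the scatter is expected in this assay, and neither direction is favoured with any confidence. The expected change is a 1.2-fold lower number from compound 1 to compound 3 (0.09 log units; within the scatter), which stays inside the scatter. For compound 3 the estimated value is 25000 nM (expected range 10000 nM to 60000 nM).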

Compound 3, half-maximal inhibitory concentration: 16300 nM
The estimate for compound 3 lay 1.5-fold (0.19 log units) above the measured number; low and high end bracket the measured number.
By their numbers in this assay, from the lowest: compounds 3, 2 and 1 (each within the scatter of the next).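

Within the data shown here, this is the first direct measure of a single swap. In this assay, putting methyl in place of fluoro on an aromatic carbon, meta to a large group, gives a 1.9-fold lower number from compound 1 to compound 3 (0.28 log units; within the scatter). A step of this size cannot be told apart from the variation between repeated measurements, so on these data fluoro and methyl at this position cannot be ranked, and the swap has no demonstrated effect on the read-out. No measurement among the data shown offers a reason for this result.

The two groups are also much alike in what can be counted: each has one heavy atom, no ring, no hydrogen-bond donors or acceptors and no net charge, so this step tests only a narrow kind of change at this position. The compounds shown therefore leave open whether a group of a different kind, such as an amine, a carboxylic acid or a longer chain, on this same aromatic carbon would move the number beyond the scatter, and in which direction.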